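The source may hold more compounds than are shown below. What is called first, only, known or untested is meant among the compounds shown, and "the series" means these compounds.

Measured so far:
- compound 1 `Cc1cc(NC(=O)Nc2ccc([N+](=O)[O-])c(C(F)(F)F)c2)c2ccccc2n1`: > 25000 nM
- compound 2 `Cc1cc(NC(=O)Nc2cc(F)ccc2F)c2ccccc2n1`: 12000 nM
- compound 3 `Cc1cc(NC(=O)Nc2ccc(N)cc2)c2ccccc2n1`: > 25000 nM

In an ADME assay on HEK293 cells (Homo sapiens) for cytotoxicity, with a stated time of 72 h (on this read-out higher numbers stand for an effect only at larger amounts of compound and lower numbers for an effect already at smaller amounts), compound 1 gives > 25000 nM, which is a limit of the assay and not a number. Compound 3 likewise gives > 25000 nM, again a limit. Compound 2 gives 12000 nM in this assay. Going by the values given here, compound 1 therefore stands at the limit of > 25000 nM in this assay, at which 2 of the 3 values shown sit, and no step between two measured compounds is available. Compound 4 `Cc1cc(NC(=O)Nc2cccc(C(F)(F)F)c2)c2ccccc2n1` has not yet been measured. It differs from compound 1 as hydrogen in place of nitro on an aromatic carbon. With most of the series sitting at the limit, the expected step is a number no higher from compound 1 to compound 4 (the limit leaves the size open), that is, none beyond the usual scatter of this assay. Compound 4 is expected near 25000 nM, within the range 10000 nM to 50000 nM, with a fair chance that only a limit is again reported.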

Compound 4, half-maximal effective concentration: 16000 nM
For compound 4 the middle estimate is 1.6-fold (0.19 log units) above the measured one, and the stated range covers the measured number.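

In this assay, going by these compounds alone, the only one-place pair so far shows hydrogen in place of nitro, ortho to a trifluoromethyl group, with an at least 1.5-fold lower number from compound 1 to compound 4 (0.19 log units; that floor lies within the scatter). Compound 1 gives > 25000 nM, which is a limit of the assay and not a number. Compound 4, without the nitro group, gives a measured 16000 nM. Going by these compounds, the true size of this step remains unknown and could be larger than stated.

On these data alone, whether a nitrile or an amine in place of nitro at this position would give a number or a limit stays open.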